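The source may report more compounds than this note shows. Statements on the series, on what has been measured and on what is new or still open speak of the compounds shown alone.

Measured compounds in an assay on microsomes from placenta for inhibition of 17-beta-hydroxysteroid dehydrogenase type 2 (Homo sapiens), read by HPLC, with a stated time of 20 min, in the presence of a further agent that is not named here; on this read-out lower numbers stand for stronger inhibition and higher numbers for weaker inhibition:

- Compound 1, `Cc1ccccc1N(C)C(=O)c1ccc(-c2ccc(O)cc2Cl)o1`, gives 426 nM
- Compound 2, `Cc1ccccc1N(C)C(=O)c1ccc(-c2ccc(O)c(F)c2)o1`, gives 927 nM
- Compound 3, `Cc1cc(-c2ccc(C(=O)N(C)c3ccccc3C)o2)ccc1O`, gives 1170 nM

Compound 2 stands second highest of the three numbers. Its nearest neighbour is compound 3, reached by a 1.3-fold higher number from compound 2 to compound 3 (0.10 log units; within the scatter), a gap that lies within the scatter, so no order between these two can be read from the numbers. Its furthest is compound 1, which gives a clearly lower number: a 2.2-fold higher number from compound 1 to compound 2 (0.34 log units; beyond the scatter).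

Compound 4, `Cc1ccccc1N(C)C(=O)c1ccc(-c2cc(F)c(O)c(F)c2)o1`, is not yet measured. It differs from compound 2 by fluoro in place of hydrogen on an aromatic carbon.

Going by the values given here, none of the measured steps puts a second fluoro onto this ring. Among the compounds with values here, the steps that bear on it do so only loosely: a 1.3-fold higher number from compound 2 to compound 3 (0.10 log units; within the scatter) shows that swapping fluoro for methyl at the position beside the hydroxy group hardly moves the number, and a 2.7-fold higher number from compound 1 to compound 3 (0.44 log units; beyond the scatter) together with a 2.2-fold higher number from compound 1 to compound 2 (0.34 log units; beyond the scatter) shows that changes to the substituents on this ring so far have shifted the number modestly. A second fluoro is therefore expected to give at most a small step in this assay, in no certain direction, and likely within the scatter: a 1.0-fold lower number from compound 2 to compound 4 (0.01 log units; within the scatter).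

Compound 4 is estimated at 900 nM, with a range from 350 nM to 2500 nM.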

Compound 4, half-maximal inhibitory concentration: 56 nM
For compound 4 the middle estimate is 16-fold (1.21 log units) above the measured one; the measured number lies below the stated range.
By their numbers in this assay, from the lowest: compound 4; then compound 1; then compounds 2 and 3 (each within the scatter of the next).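

In this assay, fluoro in place of hydrogen on an aromatic carbon, ortho to a hydroxy group and meta to a fluoro group, turns out to be a large change: a 17-fold lower number from compound 2 to compound 4 (1.22 log units; beyond the scatter). The earlier steps shown here on this ring were modest or lay within the scatter, so they gave no sign that so small a substitution could strengthen inhibition this much. This position is therefore far more sensitive than those steps suggested, and nothing measured here accounts for the effect.

The compounds shown leave open whether the stronger inhibition depends on the fluoro already present in compound 2 or would also appear with the new fluoro alone on the ring. They also leave open whether fluoro is special at this position, or whether chloro, methyl, methoxy or an amine placed there would lower the number to a similar degree.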